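Two Fluorines Out, One Chlorine In: Compound 4

The compounds below may be only part of what the source reports. "The series", "measured", "known", "first", "only" and "open" are said of these compounds alone.

Compound 1, `COc1cc(-c2nnc(SCc3ccccc3[N+](=O)[O-])o2)ccc1O`: in a functional assay on cells (T-cell, Mus musculus, strain BALB/c) for inhibition, read by MTT assay, with stated times of 24 h and 72 h (on this read-out lower numbers stand for stronger inhibition and higher numbers for weaker inhibition), compound 1 gives 9600 nM.
Compound 2, `COc1cc(-c2nnc(SCc3ccccc3F)o2)ccc1O`: in this assay compound 2 gives 5790 nM.
Compound 3, `COc1cc(-c2nnc(SCc3c(F)cccc3F)o2)ccc1O`: in this assay compound 3 gives 10100 nM.

All three share one core and differ only in the ring that hangs on a saturated chain carbon bound to a sulfur. Compound 3 gives the highest of the three numbers, but both compound 1 and compound 2 lie within the scatter of it, so no order among them can be read from these values.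

Compound 4, `COc1cc(-c2nnc(SCc3ccccc3Cl)o2)ccc1O`, has not yet been measured. Its difference from compound 3 is 2-chlorophenyl in place of 2,6-difluorophenyl on a saturated chain carbon bound to a sulfur. Among the compounds with values here, two measured steps bear on it. Adding a second fluorine gave a 1.7-fold higher number from compound 2 to compound 3 (0.24 log units; within the scatter), and exchanging a nitro for a fluoro gave a 1.7-fold lower number from compound 1 to compound 2 (0.22 log units; within the scatter); neither moved the number beyond the scatter. Replacing one halogen pattern on this ring with another is therefore expected to give a step of a 1.3-fold lower number from compound 3 to compound 4 (0.13 log units; within the scatter), that is, nothing beyond the scatter. Compound 4 is estimated to give 7500 nM, with a likely range from 3000 nM to 19000 nM.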

Compound 4, half-maximal inhibitory concentration: 8430 nM
The estimate for compound 4 lay 1.1-fold (0.05 log units) below the measured number, and the stated range covers the measured number.
By their numbers in this assay, from the lowest: compounds 2, 4, 1 and 3 (each within the scatter of the next).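

Replacing the 2,6-difluorophenyl on a saturated chain carbon bound to a sulfur with 2-chlorophenyl does not separate the two compounds in this assay (a 1.2-fold lower number from compound 3 to compound 4 (0.08 log units; within the scatter)). The same holds for chloro in place of fluoro (a 1.5-fold higher number from compound 2 to compound 4 (0.16 log units; within the scatter)) and for chloro in place of nitro (a 1.1-fold lower number from compound 1 to compound 4 (0.06 log units; within the scatter)), so a chloro joins the nitro, the fluoro and the pair of fluorines as one more ring pattern that these numbers cannot tell apart, and every step among the compounds shown stays within the scatter. No further measurement is available that could say what lies behind this result.

As far as these compounds go, all four compounds carry only halogens or a nitro on this ring and share the same core, so it remains open whether an amine or a carboxylic acid on the ring would give a number beyond the scatter. A longer chain between the sulfur and the ring, or a change to the shared core itself, is equally untested by these values, and either might show whether anything in this series can move the number further.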